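The source may hold more compounds than are shown below. What is called first, only, known or untested is meant among the compounds shown, and "the series" means these compounds.

Compound 1 `COc1ccc(/C=C/C=C/C(=O)c2ccc(C)cc2)cc1`: "not determined" (no result reported)
Compound 2 `COc1ccc(/C=C/C=C/C(=O)c2ccc[nH]2)cc1`: > 100000 nM

In an ADME assay on RAW264.7 cells (Mus musculus) for cytotoxicity, read by MTT assay (a lower number here means a stronger inhibitor, a higher number a weaker inhibitor), compound 1 has no result, which leaves compound 2 as the only reference point. Compound 2 gives > 100000 nM, and this is a limit of the assay, not a number.

Compound 3 `COc1ccc(/C=C/C=C/C(=O)c2cccs2)cc1` carries thiophen-2-yl in place of 1H-pyrrol-2-yl on a carbonyl carbon. Going by the values given here, no measured pair shows what such a swap does in this assay, so the estimate is a cautious one. The expected step of an at least 1.2-fold lower number from compound 2 to compound 3 (0.09 log units; that floor lies within the scatter) stays within the scatter. For compound 3 the estimated value is 80000 nM, with an expected range of 25000 nM to 200000 nM.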

Compound 3, half-maximal inhibitory concentration: 68500 nM
Compound 3: the middle estimate sits 1.2-fold (0.07 log units) above what was measured; the range from low to high includes it.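

With thiophen-2-yl on the carbonyl carbon, compound 3 is the first compound shown to give an actual number in this assay: 68500 nM. Putting thiophen-2-yl in place of 1H-pyrrol-2-yl gives an at least 1.4-fold lower number from compound 2 to compound 3 (0.16 log units; that floor lies within the scatter), and that floor alone does not establish a real change. The full size of the step cannot be read, since compound 2 gives a limit and not a number: the limit of > 100000 nM in this assay, at which 1 of the 3 values shown sits.

Compound 1 has no result, so it adds no comparison at this position. On these data alone, how an amine or a carboxylic acid on the thiophen-2-yl would affect the reading remains open.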